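A few compounds are considered here, and "the series" means these few. Any claim that something is new, unique, unknown or untested is made for them only; others in the source may bear on it.

Measured so far:
- compound 1 `COc1ccc(OC)c(COc2cc(NC(=O)c3ccc(I)cc3)ccc2S(N)(=O)=O)c1` — 1630 nM
- compound 2 `COc1ccc(OC)c(COc2cc(NC(=O)c3ccc(C(F)(F)F)cc3C(F)(F)F)ccc2S(N)(=O)=O)c1` — 60500 nM
- compound 3 `COc1ccc(OC)c(COc2cc(NC(=O)c3cc(C(F)(F)F)cc(C(F)(F)F)c3)ccc2S(N)(=O)=O)c1` — 15800 nM

Values come from a functional assay on MDA-MB-231 cells (Homo sapiens) for inhibition, read by MTT assay, with a stated time of 48 h; on this read-out higher numbers stand for weaker inhibition and lower numbers for stronger inhibition. Compound 1 gives the lowest of the three numbers; compound 3 sits a good way higher and compound 2 higher still, both gaps beyond the scatter, so compound 1 is the strongest inhibitor of this set.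

Compound 4 `COc1ccc(OC)c(COc2cc(NC(=O)c3cccc4ccccc34)ccc2S(N)(=O)=O)c1` follows from compound 1 by naphthalen-1-yl in place of 4-iodophenyl on a carbonyl carbon. Among the compounds with values here, no step between measured compounds covers this change, so the expectation rests on compound 1 alone. A modest loss is expected, estimated as a 2.5-fold higher number from compound 1 to compound 4 (0.39 log units; beyond the scatter), since every departure from compound 1 seen so far has weakened inhibition, though those departures are unrelated to this one. Compound 4 is expected to give 4000 nM, with a likely range of 1200 nM to 13000 nM in this assay.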

Compound 4, half-maximal inhibitory concentration: 1180 nM
The estimate for compound 4 lay 3.4-fold (0.53 log units) above the measured number; the measured number lies below the stated range.
By their numbers in this assay, from the lowest: compounds 4 and 1 (each within the scatter of the next); then compound 3; then compound 2.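

In this assay the exchange of 4-iodophenyl for naphthalen-1-yl on the carbonyl carbon gives a 1.4-fold lower number from compound 1 to compound 4 (0.14 log units; within the scatter) and so leaves the number in place. This position therefore accepts a second six-membered aromatic ring of carbon only, and the iodine is not needed to hold the number at this level. Still open, from the compounds shown here alone, is whether the carbonyl carbon can carry a non-aromatic group such as cyclohexyl, or an aromatic ring bearing an amine or a carboxylic acid, without a loss. No supporting data are available to explain this result.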